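Nitrofuranyl enones: aryl ketone variation and Vero cell cytotoxicity

The source may hold more compounds than are shown below. What is called first, only, known or untested is meant among the compounds shown, and "the series" means these compounds.

Measured so far in an ADME assay on Vero cells (Chlorocebus sabaeus) for cytotoxicity, read by resazurin assay, with a stated time of 72 h; on this read-out higher numbers stand for lower toxicity in this test and lower numbers for higher toxicity in this test:
compound 1 `Cc1ccccc1C(=O)/C=C/c1ccc([N+](=O)[O-])o1` gives 41300 nM
compound 2 `CSc1ccc(C(=O)/C=C/c2ccc([N+](=O)[O-])o2)cc1` gives 40700 nM
compound 3 `O=C(/C=C/c1ccc([N+](=O)[O-])o1)c1cccc(Br)c1` gives 68800 nM

Compound 2 holds the lowest of the three numbers in this assay. Compound 1 sits nearest to it, and compound 3 furthest, yet both gaps fall within the usual scatter of repeated measurements, so the three compounds cannot be told apart on the numbers shown. Within the data shown here, no step between two measured compounds that differ in a single place is available in this set.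

Compound 4 `O=C(/C=C/c1ccc([N+](=O)[O-])o1)c1ccc(-c2ccccc2)cc1` remains to be measured in this assay. Against compound 2 the change is phenyl in place of methylsulfanyl on an aromatic carbon, in short phenyl in place of methylsulfanyl on an aromatic carbon, para to a large group. With three aryl ketone variants all landing close together, no step beyond the scatter is expected in this assay for the change from compound 2 to compound 4; the expected step is a 1.0-fold lower number from compound 2 to compound 4 (0.01 log units; within the scatter). For compound 4 the estimate in this assay is 40000 nM, within a range from 15000 nM to 100000 nM.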

Compound 4, half-maximal cytotoxic concentration: > 100000 nM
Compound 4: no number, only a limit; the forecaster's own chance of this, stated with the estimate: 15%; middle value at least 2.5-fold (0.39 log units) away from the limit.
By their numbers in this assay, from the lowest: compounds 2, 1 and 3 (each within the scatter of the next). At a limit, above all of these: compound 4.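

In this assay, phenyl in place of methylsulfanyl on an aromatic carbon, para to a large group, gives an at least 2.4-fold higher number from compound 2 to compound 4 (0.39 log units; beyond the scatter). Among these compounds, this is the only single-place step available, and it shows that this position can move the read-out beyond the scatter, towards lower toxicity in this test, which the earlier compounds could not show. The reading for compound 4 is a limit and not a number: the limit of > 100000 nM in this assay, at which 1 of the 4 values shown sits.

Going by these compounds, the full size of the step stays open, as does whether another ring on this aromatic carbon would give the same result. Also open, on these data alone, is how an amine, a carboxylic acid or a longer chain in the same place would compare with methylsulfanyl and phenyl.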